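A Difluorophenyl Swap on the Amide Nitrogen of Compound 3

The source may report more compounds than this note shows. Statements on the series, on what has been measured and on what is new or still open speak of the compounds shown alone.

Compound 3 `CCN1CCc2c(c(C(C)(C)C)nn2C(=O)Nc2cc(C)ccc2C)C1` gives 15.7% in a functional assay on the whole organism (strain Swiss albino) for inhibition, with Mus musculus as the target, in the formalin test, with a stated time of 30 min, at a dose of 100 mg/kg (a lower number here means less inhibition, a higher number more inhibition at the dose given (going by the name of the read-out)), the second highest of the three numbers; compound 1 `CCN1CCc2c(c(C)nn2C(=O)Nc2ccc(F)cc2F)C1` gives 14.3%, within the scatter of compound 3, while compound 2 `CCN1CCc2c(c(C(C)(C)C)nn2C(=O)Nc2ccc(Br)cc2)C1` gives 72.1%. Among the measured compounds shown here, the one measured step, a number 56.4 percentage points lower from compound 2 to compound 3 (beyond the scatter), shows that the group on the amide-type nitrogen can move the number far. Compound 4 `CCN1CCc2c(c(C(C)(C)C)nn2C(=O)Nc2ccc(F)cc2F)C1` differs from compound 3 by 2,4-difluorophenyl in place of 2,5-dimethylphenyl on an amide-type nitrogen. For the measured compounds named here, no measured step covers this exact exchange; compound 1 carries the same 2,4-difluorophenyl on its amide-type nitrogen and gives 14.3%. A modest rise is therefore expected, a number 9.3 percentage points higher from compound 3 to compound 4 (within the scatter), with wide uncertainty. Compound 4 is estimated at 25%, within 8% to 55%.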

Compound 4, a percentage reported as inhibition, in the whole organism at one dose (the size of the read-out at that dose, not a potency): 73.4%
Beside the measured number, compound 4's estimate is 48.4 percentage points below it; the measured number lies above the stated range.
By their numbers in this assay, from the lowest: compounds 1 and 3 (each within the scatter of the next); then compounds 2 and 4 (each within the scatter of the next).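

With the tert-butyl group kept, the group on the amide-type nitrogen sets the outcome in this assay: 2,4-difluorophenyl in place of 2,5-dimethylphenyl gives a number 57.7 percentage points higher from compound 3 to compound 4 (beyond the scatter) while 2,4-difluorophenyl in place of 4-bromophenyl gives a number 1.3 percentage points higher from compound 2 to compound 4 (within the scatter) so that both halogen-bearing rings stand apart from the dimethyl one here. The 2,4-difluorophenyl group does not suffice alone, since tert-butyl in place of methyl on an aromatic carbon gives a number 59.1 percentage points higher from compound 1 to compound 4 (beyond the scatter) and so a second place on the core also moves the number.

As far as these compounds go, whether a 4-chlorophenyl or a pyridyl group on the amide-type nitrogen, or an isopropyl group in place of tert-butyl, would hold this level stays open. Nothing given here explains these steps.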